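This account rests on a few compounds, and the source may have more. Where it says the series, first, only, none or still open, it means among the compounds named here.

Measured in a functional assay on A549 cells (Homo sapiens) for cytotoxicity, read by MTT assay, with a stated time of 48 h; on this read-out lower numbers stand for stronger inhibition and higher numbers for weaker inhibition:
- compound 1 `C=C1C(=O)O[C@H]2CC3=C[C@H](C/C(C)=C/[C@@H](OC(=O)c4ccc(C(C)=O)cc4)[C@H]12)OC3=O`: 2300 nM
- compound 2 `C=C1C(=O)O[C@H]2CC3=C[C@H](C/C(C)=C/[C@@H](OC(=O)/C=C/c4ccccc4)[C@H]12)OC3=O`: 4800 nM

Compound 2 has the higher of the two numbers in this assay. Compound 3 `C=C1C(=O)O[C@H]2CC3=C[C@H](C/C(C)=C/[C@@H](OC(=O)CCl)[C@H]12)OC3=O` carries chloromethyl in place of 2-phenylethenyl on a carbonyl carbon. One measured change at this carbonyl carbon bears on it, the modest 2.1-fold higher number from compound 1 to compound 2 (0.32 log units; beyond the scatter). That change involves a different incoming group, so it suggests a size but gives no firm direction. A similarly modest shift is expected, tentatively toward a lower number. The estimated step is a 1.5-fold lower number from compound 2 to compound 3 (0.18 log units; within the scatter). The estimate for compound 3 is 3200 nM, with an expected range from 1100 nM to 9500 nM.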

Compound 3, half-maximal inhibitory concentration: > 10000 nM
Compound 3: only a limit was reported; the forecaster's own chance of this, stated with the estimate: 4%; middle value at least 3.1-fold (0.49 log units) away from the limit.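

In this assay compound 3 gives > 10000 nM, which is a limit of the assay and not a number. At this carbonyl carbon, both groups carrying a six-membered aromatic ring give lower numbers than chloromethyl, with an at least 2.0-fold higher number from compound 2 to compound 3 (0.31 log units; beyond the scatter) and an at least 4.3-fold higher number from compound 1 to compound 3 (0.63 log units; beyond the scatter). These steps are lower bounds only: the limit of > 10000 nM in this assay, at which 1 of the 3 values shown sits.

The compounds shown cannot separate the loss of the aromatic ring from the entry of chlorine. On these data alone, whether a plain methyl or an unsubstituted phenyl on this carbonyl carbon would fall with compound 1 and compound 2 or with compound 3 stays open.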